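A Thiophene for a Furan on the Saturated Ring Carbon

A few compounds are considered here, and "the series" means these few. Any claim that something is new, unique, unknown or untested is made for them only; others in the source may bear on it.

Of the compounds shown here, three that share one core have been measured in an assay on membranes from HEK293 cells for displacement of a labelled ligand from adenosine receptor A2b (Homo sapiens), read by scintillation counting, with a stated time of 30 min, tested at 1 uM; a lower number here means less inhibition, a higher number more inhibition at the concentration tested (going by the name of the read-out). Compound 1 `CC1=C(C(=O)OC(C)(C)C)C(c2ccsc2)NC(=O)N1` gives 47%, the highest number of the three. Compound 2 `CC1=C(C(=O)C2CC2)C(c2ccsc2)NC(=O)N1` gives 1%, and the change between them, cyclopropyl in place of tert-butoxy on a carbonyl carbon, produced a number 46 percentage points lower from compound 1 to compound 2 (beyond the scatter). Compound 3 `CC1=C(C(N)=O)C(c2ccoc2)NC(=O)N1` gives 6%; it stands second highest of the three, within the scatter of compound 2 and well below compound 1.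

The next compound, compound 4 `CC1=C(C(N)=O)C(c2ccsc2)NC(=O)N1`, differs from compound 3 in one place: thiophen-3-yl in place of furan-3-yl on a saturated ring carbon. Among the measured compounds shown here, no measured pair shows this exchange directly; the only measured step, from compound 1 to compound 2, concerns the group on the carbonyl carbon and is large, but the carbamoyl group of compound 3 is kept in compound 4. The two compounds that carry thiophen-3-yl, compound 1 and compound 2, span nearly the whole range, so the ring on the saturated carbon alone does not set the number. Compound 4 is therefore expected to move by a number 4 percentage points higher from compound 3 to compound 4 (within the scatter), a step not beyond the scatter. Compound 4 is estimated at 10%, with a range from 0% to 30%.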

Compound 4, a percentage reported as inhibition, at one concentration (the size of the read-out at that concentration, not a potency): 1%
For compound 4 the middle estimate is 9 percentage points above the measured one, and the stated range covers the measured number.
By their numbers in this assay, from the lowest: compounds 2, 4 and 3 (each within the scatter of the next); then compound 1.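

With the carbamoyl group held on the neighbouring ring atom, the exchange of furan-3-yl for thiophen-3-yl on the saturated ring carbon can now be read directly in this assay and gives a number 5 percentage points lower from compound 3 to compound 4 (within the scatter), so this pair does not separate the two rings at this low level. With thiophen-3-yl held, amino in place of cyclopropyl on the carbonyl carbon gives no change at the digits printed from compound 2 to compound 4 (within the scatter), whereas amino in place of tert-butoxy gives a number 46 percentage points lower from compound 1 to compound 4 (beyond the scatter) and so matches the size of the earlier step from tert-butoxy to cyclopropyl. Among the three compounds that carry thiophen-3-yl, only compound 1, with tert-butoxy, stands apart, and the ring exchange has been read only with amino on the carbonyl carbon.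

Still open, going by these compounds, is whether the ring exchange would read the same with tert-butoxy on the carbonyl carbon, and what a phenyl ring on the saturated ring carbon or an ethoxy group on the carbonyl carbon would give. No measurement offered here explains any of these steps.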